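Swapping the Aryl Group on the Fused Core

The source may report more compounds than this note shows. Statements on the series, on what has been measured and on what is new or still open speak of the compounds shown alone.

Compound 1 `Cn1ccc2c(Oc3ccc(NC(=O)c4cc5cccnc5n(-c5ccc(C(F)(F)F)cc5Cl)c4=O)cc3)ccnc21`: 12600 nM
Compound 2 `Cn1ccc2c(Oc3ccc(NC(=O)c4cc5cccnc5n(-c5ccccc5)c4=O)cc3F)ccnc21`: 3590 nM
Compound 3 `Cn1ccc2c(Oc3ccc(NC(=O)c4cc5cccnc5n(-c5ccc(Br)cc5)c4=O)cc3F)ccnc21`: 2580 nM

Of the compounds shown here, three that share one core have been measured in a functional assay on U-87MG ATCC cells for antiproliferative activity against U-87 MG (Homo sapiens), read by MTT assay, with a stated time of 72 h; a higher number here means a weaker inhibitor, a lower number a stronger inhibitor. Compound 1 gives 12600 nM, compound 2 gives 3590 nM, and compound 3 gives 2580 nM. Compound 3 carries the lowest number of the three: its gap to compound 2 lies within the scatter, while its gap to compound 1 lies beyond it. Among the measured compounds shown here, the one single-place step among them is a 1.4-fold lower number from compound 2 to compound 3 (0.14 log units; within the scatter).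

Compound 4 `Cn1ccc2c(Oc3ccc(NC(=O)c4cc5cccnc5n(-c5ccc(C(F)(F)F)cc5Cl)c4=O)cc3F)ccnc21` has not yet been measured. It differs from compound 3 by 2-chloro-4-(trifluoromethyl)phenyl in place of 4-bromophenyl on an aromatic nitrogen. For the measured compounds named here, no measured step covers this exact change; the bromo-for-hydrogen step bears on it only loosely and was itself within the scatter. What the data do offer is compound 1, which carries the same entering group and gives the highest number of the set, though compound 1 also differs from compound 4 in a second place, so its value can only be read as a hint.

On that basis compound 4 is expected to show a higher number than compound 3, a step of a 2.7-fold higher number from compound 3 to compound 4 (0.43 log units; beyond the scatter). The estimate for compound 4 is 7000 nM, in a range from 2500 nM to 20000 nM.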

Compound 4, half-maximal inhibitory concentration: 10200 nM
Compound 4: the middle estimate sits 1.5-fold (0.16 log units) below what was measured; the range from low to high includes it.
By their numbers in this assay, from the lowest: compounds 3 and 2 (each within the scatter of the next); then compounds 4 and 1 (each within the scatter of the next).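

In this assay, the aryl group on the aromatic nitrogen now proves able to move the number: 2-chloro-4-(trifluoromethyl)phenyl in place of 4-bromophenyl gives a 4.0-fold higher number from compound 3 to compound 4 (0.60 log units; beyond the scatter) and in place of phenyl gives a 2.8-fold higher number from compound 2 to compound 4 (0.45 log units; beyond the scatter), whereas the earlier change from phenyl to 4-bromophenyl stayed within the scatter. The other single-place change, the added fluoro, gives a 1.2-fold lower number from compound 1 to compound 4 (0.09 log units; within the scatter) and so leaves the number within the scatter, which ties the high values of this pair to the shared 2-chloro-4-(trifluoromethyl)phenyl group rather than to that fluoro. Nothing available gives a measured reason for the rise that comes with this group.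

The entering group brings a chlorine and a trifluoromethyl together, so the compounds shown cannot say which of the two goes with the higher number, or whether only the pair does. Also open, going by these compounds, is how the number would respond to an aryl group carrying an amine or a methoxy group at this position, and whether any such group would take it clearly lower than phenyl does.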